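Methyl to hydrogen on the hydroxyalkyl substituent

The compounds below may be only part of what the source reports. "The series", "measured", "known", "first", "only" and "open" are said of these compounds alone.

Three compounds share one core. Compound 1 `CCCn1c(=O)c2nc(-c3cccn3C)[nH]c2n(CCC)c1=O` gives 140 nM in an assay on cell membranes for binding affinity to adenosine receptor A1 (Cavia porcellus), read by radioligand binding; a higher number here means a weaker inhibitor, a lower number a stronger inhibitor. Compound 2 `CCCn1c(=O)c2nc([C@@H]3CC4CCC3C4)[nH]c2n(CCC)c1=O` gives 3.8 nM. Compound 3 `CCCn1c(=O)c2nc(C(O)(CC)CC)[nH]c2n(CCC)c1=O` gives 170 nM, the highest of the three numbers: it sits near compound 1 (a 1.2-fold higher number from compound 1 to compound 3 (0.08 log units; within the scatter)) and far from compound 2 (a 45-fold higher number from compound 2 to compound 3 (1.65 log units; beyond the scatter)). Compound 4 `CCCn1c(=O)c2nc(C(C)(O)CC)[nH]c2n(CCC)c1=O` differs from compound 3 by hydrogen in place of methyl on a saturated chain carbon, two bonds along the chain from an aromatic carbon and an oxygen on a saturated carbon, that is 1-ethyl-1-hydroxypropyl to 1-hydroxy-1-methylpropyl. Among the compounds with values here, no measured step removes a single carbon: the large steps of a 37-fold lower number from compound 1 to compound 2 (1.57 log units; beyond the scatter) and a 45-fold higher number from compound 2 to compound 3 (1.65 log units; beyond the scatter) exchange whole groups, and a 1.2-fold higher number from compound 1 to compound 3 (0.08 log units; within the scatter) lies within the scatter. Nothing points to a move beyond the scatter. Compound 4 is therefore expected to stay close, the expected step being a 1.3-fold higher number from compound 3 to compound 4 (0.11 log units; within the scatter). The estimate for compound 4 is 220 nM, with range 80 nM to 600 nM.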

Compound 4, inhibition constant: 240 nM
For compound 4 the middle estimate is 1.1-fold (0.04 log units) below the measured one; low and high end bracket the measured number.
By their numbers in this assay, from the lowest: compound 2; then compounds 1, 3 and 4 (each within the scatter of the next).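

In this assay, within the data shown here, this is the first step that removes a single carbon, and a 1.4-fold higher number from compound 3 to compound 4 (0.15 log units; within the scatter) shows that going from 1-ethyl-1-hydroxypropyl to 1-hydroxy-1-methylpropyl gives no change that can be read. The shorter group leaves the large gap to compound 2 in place, with a 63-fold higher number from compound 2 to compound 4 (1.80 log units; beyond the scatter) as the step, while a 1.7-fold higher number from compound 1 to compound 4 (0.23 log units; within the scatter) also stays within the scatter. No evidence is available on why this shortening changes so little.

On these data alone, whether a longer chain than ethyl at this carbon, or an amine in place of the hydroxyl, would move the number beyond the scatter remains open.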